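This account rests on a few compounds, and the source may have more. Where it says the series, first, only, none or still open, it means among the compounds named here.

Working notes on the series, read in a functional assay on SK-MEL-2 cells (Homo sapiens) for inhibition, with a stated time of 72 h; on this read-out lower numbers stand for stronger inhibition and higher numbers for weaker inhibition.

Compound 1 `CCC1(c2ccccc2)CC(=O)C(C2CC(c3ccc(-c4ccc(Br)cc4)cc3)Cc3ccccc32)=C(O)O1` returns only a limit in this assay, > 10000 nM. Compound 2 `CCC1(c2ccccc2)CC(=O)C(C2CC(c3ccc(OCc4ccc(C(F)(F)F)cc4)cc3)Cc3ccccc32)=C(O)O1` likewise returns only a limit, > 10000 nM. The step that the two limits leave unreadable from compound 1 to compound 2 rests on the change ((4-(trifluoromethyl)benzyl)oxy in place of 4-bromophenyl on an aromatic carbon). Compound 3 `CCCC1(CCc2ccccc2)CC(=O)C(C2CC(c3ccc(-c4ccc(Br)cc4)cc3)Cc3ccccc32)=C(O)O1` also returns only a limit, > 10000 nM. How the core of compound 3 differs from the core of compound 1 is not broken down here. Every value shown sits at the limit of > 10000 nM in this assay, at which 3 of the 3 values shown sit.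

Compound 4 `CCCC1(CCc2ccccc2)CC(=O)C(C2CC(c3ccc(OCc4ccc(C(F)(F)F)cc4)cc3)Cc3ccccc32)=C(O)O1` is not yet measured. It differs from compound 3 by (4-(trifluoromethyl)benzyl)oxy in place of 4-bromophenyl on an aromatic carbon, the same change as that from compound 1 to compound 2, at the same place. For the measured compounds named here, the step from compound 3 to compound 4 is expected to be a step that the limit leaves unreadable from compound 3 to compound 4, as unreadable as the earlier step, because the limit of > 10000 nM in this assay, at which 3 of the 3 values shown sit, holds all three values so far. Compound 4 is therefore estimated at 15000 nM, most probably reported again as a limit rather than a number.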

Compound 4, half-maximal inhibitory concentration: > 10000 nM
Compound 4: no number, only a limit; the forecaster's own chance of this, stated with the estimate: 85%; the middle value is on the limit's open side.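

No step can be read between compound 3 and compound 4, since both give only a limit in this assay: the limit of > 10000 nM in this assay, at which 4 of the 4 values shown sit. The compounds shown leave open whether the change from 4-bromophenyl to (4-(trifluoromethyl)benzyl)oxy has any effect on inhibition.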